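The source may hold more compounds than are shown below. What is called first, only, known or untested is meant among the compounds shown, and "the series" means these compounds.

Compound 1 `COc1cc(-c2nn(-c3cccc(NC(=O)Nc4cccc(C(F)(F)F)c4)c3)cc2-c2ccncc2)ccc1Cl` gives 4000 nM in a functional assay on SNB-19 cells (Homo sapiens) for inhibition, read by sulforhodamine B assay, with a stated time of 48 h; a higher number here means a weaker inhibitor of growth, a lower number a stronger inhibitor of growth.
Compound 2 `COc1cc(-c2nn(-c3cccc(NC(=O)c4ccc(Cl)c(C(F)(F)F)c4)c3)cc2-c2ccncc2)ccc1Cl` gives > 32500 nM in this assay.

The value of compound 2 is a limit of the assay and not a number, so compound 2 sits at the weak end of what has been measured (the limit of > 32500 nM in this assay, at which 1 of the 2 values shown sits). Compound 3 `COc1cc(-c2nn(-c3cccc(NC(=O)Nc4ccc(Cl)c(C(F)(F)F)c4)c3)cc2-c2ccncc2)ccc1Cl` has not yet been measured; it differs from compound 2 by (4-chloro-3-(trifluoromethyl)phenyl)amino in place of 4-chloro-3-(trifluoromethyl)phenyl on a carbonyl carbon. Within the data shown here, one measured step bears on this change, though only in part: an at least 8.1-fold higher number from compound 1 to compound 2 (0.90 log units; beyond the scatter) combined the same kind of change on the carbonyl carbon, taken in the other direction, with a change on the outer ring. Restoring the amino link on the carbonyl carbon is therefore expected to give a clearly lower number in this assay, with the expected step being an at least 10-fold lower number from compound 2 to compound 3 (1.03 log units; beyond the scatter). Compound 3 is estimated at 3000 nM, in a range from 800 nM to 12000 nM.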

Compound 3, concentration for total growth inhibition: 9240 nM
Compound 3: middle estimate off by 3.1-fold (0.49 log units), on the low side; the measured number falls inside the stated range.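

Changing only the link on the carbonyl carbon, with the 4-chloro-3-(trifluoromethyl)phenyl ring kept, gives an at least 3.5-fold lower number from compound 2 to compound 3 (0.54 log units; beyond the scatter), so the amino link matters by itself, which the earlier pair could not show because it also changed the outer ring. The size of this step is only a minimum because the value of compound 2 is a limit of the assay and not a number: the limit of > 32500 nM in this assay, at which 1 of the 3 values shown sits. Taken alone, the chloro on the outer ring gives a 2.3-fold higher number from compound 1 to compound 3 (0.36 log units; beyond the scatter), a modest weakening that separates its effect from that of the link.

As far as these compounds go, it remains open whether the amide hydrogen of the amino link is what counts, which a methylamino link could test. From the compounds shown here alone, it also remains open how a fluoro or methoxy group would compare with the chloro.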